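The source may hold more compounds than are shown below. What is called first, only, known or untested is meant among the compounds shown, and "the series" means these compounds.

Measured compounds:
- compound 1, `CCCCCCNc1nc(-c2ccccc2)nc2c1nnn2Cc1ccccc1`: 13200000 nM
- compound 2, `CCCNc1nc(-c2ccccc2)nc2c1nnn2Cc1ccccc1`: 37000000 nM
- compound 3, `c1ccc(Cn2nnc3c(NC4CC4)nc(-c4ccccc4)nc32)cc1`: 11000000 nM

All three were tested in an assay on isolated protein for binding affinity to adenosine receptor A1 (Bos taurus); a higher number here means a weaker inhibitor, a lower number a stronger inhibitor. Compound 3 gives the lowest of the three numbers in this assay, though compound 1 sits within the scatter of it; only compound 2 stands apart, as a 3.4-fold lower number from compound 2 to compound 3 (0.53 log units; beyond the scatter) shows.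

Compound 4, `CCCCNc1nc(-c2ccccc2)nc2c1nnn2Cc1ccccc1`, has not yet been measured in this assay. It differs from compound 3 in one place: butyl in place of cyclopropyl on a nitrogen on an aromatic ring

For the measured compounds named here, two measured steps bear on this change. Going from the cyclopropyl to a propyl chain gave a 3.4-fold lower number from compound 2 to compound 3 (0.53 log units; beyond the scatter) read in reverse, a modest rise in the number, whereas the longer hexyl chain gave a 1.2-fold lower number from compound 1 to compound 3 (0.08 log units; within the scatter), a difference within the scatter. Butyl lies between those two chain lengths, so compound 4 is expected to land between compound 2 and compound 1, with a small step upward from compound 3, a 1.8-fold higher number from compound 3 to compound 4 (0.26 log units; within the scatter), that may or may not clear the scatter. Compound 4 is therefore estimated at 20000000 nM in this assay, with a likely range from 8000000 nM to 50000000 nM.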

Compound 4, inhibition constant: 11000000 nM
Compound 4: the middle estimate sits 1.8-fold (0.26 log units) above what was measured; low and high end bracket the measured number.
By their numbers in this assay, from the lowest: compounds 3, 4 and 1 (each within the scatter of the next); then compound 2.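

In this assay, butyl on this nitrogen does not differ from cyclopropyl (no change at the digits printed from compound 3 to compound 4 (within the scatter)), so replacing the three-membered ring with an open chain has no readable effect at this position. The earlier compounds shown here showed propyl apart from hexyl, and butyl now shows that one further carbon on the propyl chain is enough for the whole step (a 3.4-fold lower number from compound 2 to compound 4 (0.53 log units; beyond the scatter)), while the longer hexyl chain does not differ from butyl (a 1.2-fold lower number from compound 1 to compound 4 (0.08 log units; within the scatter)). Compound 2, with propyl, is thus the only one of these compounds that stands apart, and compounds 1, 3 and 4 cannot be told apart here.

On these data alone, whether a branched chain such as isopropyl, or a chain ending in an amine, would give a similar number remains open. Nothing shown here explains why propyl stands apart from butyl.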